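From nitro to methyl: compound 3 to compound 4

This account rests on a few compounds, and the source may have more. Where it says the series, first, only, none or still open, it means among the compounds named here.

- Compound 1 `O=C(N/N=C/c1ccco1)c1ccc([N+](=O)[O-])o1`: "not determined" (no result reported)
- Compound 2 `C/C(=N\NC(=O)c1ccc([N+](=O)[O-])o1)c1ccccc1`: > 228000 nM
- Compound 3 `C/C(=N\NC(=O)c1ccc([N+](=O)[O-])o1)c1ccc([N+](=O)[O-])cc1`: > 196000 nM

The assay here is an ADME assay on Vero cells (Chlorocebus sabaeus) for cytotoxicity, read by MTT assay, with a stated time of 72 h; a lower number here means that less compound is tolerated, a higher number that more compound is tolerated. Compound 3 stands at > 196000 nM, which is a limit and not a number. Compound 4 `C/C(=N\NC(=O)c1ccc([N+](=O)[O-])o1)c1ccc(C)cc1` has methyl in place of nitro on an aromatic carbon, para to a large group (methyl in place of nitro on an aromatic carbon). Among the measured compounds shown here, the one measured step that bears on this change is a step that the two limits leave unreadable from compound 2 to compound 3, which put nitro in place of hydrogen on an aromatic carbon. Its size cannot be read, so it points in no direction, and no change beyond the scatter is expected. The expected step is a step that the limit leaves unreadable from compound 3 to compound 4. The estimate for compound 4 is 220000 nM, with an expected range from 90000 nM to 400000 nM.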

Compound 4, half-maximal cytotoxic concentration: > 217000 nM
Compound 4 gave a limit, no number; the forecaster's own chance of this, stated with the estimate: 75%; the middle value does not contradict the limit.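

Among the compounds shown here, compound 2, compound 3 and compound 4 each give only a limit, not a number, and no step between them can be read. The compounds shown leave open at what concentration any of them harms the cells, and whether hydrogen, nitro or methyl on the aromatic carbon makes any difference.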